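This account rests on a few compounds, and the source may have more. Where it says the series, first, only, none or still open, it means among the compounds named here.

Working notes on the series. The shared core carries a chlorine on the fused two-ring system and a chloromethyl-substituted benzyl group; compound 1 `ClCc1ccc(Cn2cnc3c(Cl)ncnc32)cc1` and compound 2 `ClCc1cccc(Cn2cnc3ncnc(Cl)c32)c1` have the same atoms joined differently, and the difference between the two cores is not broken down here. In a functional assay on SF-268 cells (Homo sapiens) for cytotoxicity, read by sulforhodamine B assay, with a stated time of 48 h (a higher number here means a weaker inhibitor of growth, a lower number a stronger inhibitor of growth), compound 1 gives 640 nM and compound 2 gives 1650 nM. Compound 3 `ClCc1ccc(Cn2cnc3c(Cl)nc(Cl)nc32)cc1` adds to compound 1 a chloro in place of hydrogen (chloro in place of hydrogen on an aromatic carbon); in this assay compound 3 gives 2510 nM, a step of a 3.9-fold higher number from compound 1 to compound 3 (0.59 log units; beyond the scatter). Compound 4 `ClCc1cccc(Cn2cnc3nc(Cl)nc(Cl)c32)c1` makes the same change to compound 2 (chloro in place of hydrogen on an aromatic carbon). Going by the values given here, for compound 4 the expected step is a 3.0-fold higher number from compound 2 to compound 4 (0.48 log units; beyond the scatter) in this assay, resting on the single earlier step of a 3.9-fold higher number from compound 1 to compound 3 (0.59 log units; beyond the scatter) and on compound 2 at 1650 nM. Compound 4 is thus estimated at 5000 nM, between 2200 nM and 12000 nM.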

Compound 4, concentration for 50% growth inhibition: 2130 nM
Beside the measured number, compound 4's estimate is 2.3-fold (0.37 log units) above it; measured number below the stated range.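

In this assay, chloro in place of hydrogen on an aromatic carbon gives a 1.3-fold higher number from compound 2 to compound 4 (0.11 log units; within the scatter), so on this core the change has no effect that can be told from the scatter. The size of the step therefore does not carry from one core to the other: the same change on two cores in this assay, a 3.9-fold higher number (0.59 log units; beyond the scatter) from compound 1 to compound 3 and a 1.3-fold higher number (0.11 log units; within the scatter) from compound 2 to compound 4, 3.0-fold (0.48 log units) apart, beyond the scatter of two such steps. Going by these compounds alone, these two pairs show only that the step differs between these two cores; they give no rule for any further core and do not identify which feature of the cores goes with the gap.

Open, as far as these compounds go, is whether an amine or a methoxy group on the same carbon, between two ring nitrogen atoms, would also give steps that differ between the two cores. Also open, from the compounds shown here alone, is whether the gap would persist with a longer chain in place of the chloromethyl group.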